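This account rests on a few compounds, and the source may have more. Where it says the series, first, only, none or still open, it means among the compounds named here.

Compound 3 `CCc1nc(NN2C(=O)C=C(C)C2=O)ncc1CO` closes a short series of three analogues that share one core and differ only in the group carried on the aromatic carbon next to the ethyl group. In a functional assay on Jurkat cells (Homo sapiens) for inhibition (on this read-out higher numbers stand for weaker inhibition and lower numbers for stronger inhibition), compound 3 gives 4900 nM, which is the highest number of the three. Its nearest neighbour is compound 2 `CCc1nc(NN2C(=O)C=C(C)C2=O)ncc1C(=O)c1ccccc1`, which in this assay gives 650 nM; compound 1 `CCOC(=O)c1cnc(NN2C(=O)C=C(C)C2=O)nc1CC` gives in this assay 400 nM. The two steps that lead to compound 3 were both beyond the scatter: a 12-fold higher number from compound 1 to compound 3 (1.09 log units; beyond the scatter) and a 7.5-fold higher number from compound 2 to compound 3 (0.88 log units; beyond the scatter). Between compound 1 and compound 2, by contrast, the change was small: a 1.6-fold higher number from compound 1 to compound 2 (0.21 log units; within the scatter).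

Compound 4 `CCc1nc(NN2C(=O)C=C(C)C2=O)ncc1C#N` is the next step from compound 3, carrying the change (cyano in place of hydroxymethyl on an aromatic carbon). The hydroxymethyl group, whose arrival from either carbonyl-bearing neighbour raised the number markedly, gives way to a cyano group that keeps an acceptor and brings no donor. Among the compounds with values here, because a 12-fold higher number from compound 1 to compound 3 (1.09 log units; beyond the scatter) and a 7.5-fold higher number from compound 2 to compound 3 (0.88 log units; beyond the scatter) both ran upward when hydroxymethyl entered, a move back down in this assay is expected for compound 4, though no cyano analogue has been measured and the size is uncertain. Compound 4 is therefore estimated at 1200 nM, between 400 nM and 3600 nM, an expected step of a 4.1-fold lower number from compound 3 to compound 4 (0.61 log units; beyond the scatter).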

Compound 4, half-maximal inhibitory concentration: 1100 nM
Compound 4: the middle estimate sits 1.1-fold (0.04 log units) above what was measured, and the stated range covers the measured number.
By their numbers in this assay, from the lowest: compounds 1, 2 and 4 (each within the scatter of the next, the first and the last beyond it); then compound 3.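

Replacing hydroxymethyl with cyano on this aromatic carbon recovers much of the loss seen with hydroxymethyl in this assay (a 4.5-fold lower number from compound 3 to compound 4 (0.65 log units; beyond the scatter)), so compound 3 stands apart from all three other compounds, and its high number is not shared by a group of the same size, since cyano and hydroxymethyl both have 2 heavy atoms and no ring. Cyano also stays within the scatter of benzoyl (a 1.7-fold higher number from compound 2 to compound 4 (0.23 log units; within the scatter)), which shows that a group with no ring can match one carrying a phenyl at this position, while it falls short of ethoxycarbonyl by a step beyond the scatter (a 2.8-fold higher number from compound 1 to compound 4 (0.44 log units; beyond the scatter)). No measurement here explains why these groups differ at this position.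

With only four groups compared, the shift from hydroxymethyl to cyano cannot be tied to the loss of the hydrogen-bond donor alone, and a methoxymethyl group, which would keep the oxygen without that hydrogen, would be one way to separate the two. From the compounds shown here alone, how an aminomethyl group, a carboxylic acid, an amide or a longer chain would behave on this carbon also remains open.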